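Furan positional change on the ring amide nitrogen

The source may hold more compounds than are shown below. What is called first, only, known or untested is meant among the compounds shown, and "the series" means these compounds.

Three aromatic substituents on the amide-type nitrogen in a ring of the shared core have been compared. Compound 1 `O=C(NCc1ccc(Cl)cc1Cl)[C@@H]1CCC(=O)N1c1cccs1` gives 720 nM in an assay on HEK293 cells for displacement of a labelled ligand from P2X purinoceptor 7 (Homo sapiens), read by scintillation counting, with a stated time of 1 h; a higher number here means a weaker inhibitor, a lower number a stronger inhibitor; compound 2 `O=C(NCc1ccc(Cl)cc1Cl)[C@@H]1CCC(=O)N1c1ccsc1` gives 1250 nM; compound 3 `O=C(NCc1ccc(Cl)cc1Cl)[C@@H]1CCC(=O)N1c1ccco1` gives 575 nM. Compound 3 carries the lowest of the three numbers: the step of a 1.3-fold lower number from compound 1 to compound 3 (0.10 log units; within the scatter) stays within the scatter, while the step of a 2.2-fold lower number from compound 2 to compound 3 (0.34 log units; beyond the scatter) is a modest one beyond it.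

Compound 4 `O=C(NCc1ccc(Cl)cc1Cl)[C@@H]1CCC(=O)N1c1ccoc1` has not yet been measured in this assay. It differs from compound 3 by furan-3-yl in place of furan-2-yl on an amide-type nitrogen in a ring. For the measured compounds named here, the one measured step that bears on this is the thiophene counterpart, a 1.7-fold higher number from compound 1 to compound 2 (0.24 log units; within the scatter), which remained within the scatter. Going by the values given here, no furan pair of this kind has been measured, so the thiophene step is the only guide. A small upward move is therefore expected, probably within the scatter, as the step of a 1.5-fold higher number from compound 3 to compound 4 (0.17 log units; within the scatter). Compound 4 is estimated at 850 nM, with a range from 400 nM to 1800 nM.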

Compound 4, half-maximal inhibitory concentration: 422 nM
The estimate for compound 4 lay 2.0-fold (0.30 log units) above the measured number; the range from low to high includes it.
By their numbers in this assay, from the lowest: compounds 4, 3, 1 and 2 (each within the scatter of the next, the first and the last beyond it).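

In this assay, moving the attachment point of the furan leaves the two isomers indistinguishable (a 1.4-fold lower number from compound 3 to compound 4 (0.13 log units; within the scatter)), matching the thiophene pair at this position (a 1.7-fold higher number from compound 1 to compound 2 (0.24 log units; within the scatter)). Furan-3-yl also cannot be separated from thiophen-2-yl (a 1.7-fold lower number from compound 1 to compound 4 (0.23 log units; within the scatter)), whereas the step from thiophen-3-yl is beyond the scatter (a 3.0-fold lower number from compound 2 to compound 4 (0.47 log units; beyond the scatter)), so at this position on the amide-type nitrogen in a ring, only compound 2 stands apart from the two furans. No measurement at hand accounts for these differences.

Going by these compounds, whether this position accepts groups other than five-membered aromatic rings remains open; a phenyl, a pyridyl or a cyclohexyl group on the same nitrogen would test it. Also open, on these data alone, is whether the same narrow spread would hold with an amine or a carboxylic acid on these rings.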